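Ester of the hydroxymethyl analogue: a larger group on the core

The source may hold more compounds than are shown below. What is called first, only, known or untested is meant among the compounds shown, and "the series" means these compounds.

Three compounds share one core and were tested in a functional assay on MCF7 cells (Homo sapiens) for cytotoxicity, read by neutral red uptake, with a stated time of 3 days; on this read-out higher numbers stand for weaker inhibition and lower numbers for stronger inhibition. Compound 1 `CCc1c(F)c(N)c2c(=O)cc(-c3ccc(N)c(F)c3)oc2c1F` gives 130 nM, compound 2 `Nc1ccc(-c2cc(=O)c3c(N)c(F)c(CO)c(F)c3o2)cc1F` gives 62 nM, and compound 3 `Nc1ccc(-c2cc(=O)c3c(N)c(F)c(Cl)c(F)c3o2)cc1F` gives 210 nM. Compound 3 has the highest number of the three: the step of a 1.6-fold higher number from compound 1 to compound 3 (0.21 log units; within the scatter) is small, whereas the step of a 3.4-fold higher number from compound 2 to compound 3 (0.53 log units; beyond the scatter) is a clear rise. Compound 4 `CCC(=O)OCc1c(F)c(N)c2c(=O)cc(-c3ccc(N)c(F)c3)oc2c1F` is not yet measured. It differs from compound 3 by (propanoyloxy)methyl in place of chloro on an aromatic carbon. Within the data shown here, the steps that bear on this change are a 1.6-fold higher number from compound 1 to compound 3 (0.21 log units; within the scatter) and a 3.4-fold higher number from compound 2 to compound 3 (0.53 log units; beyond the scatter), both of which describe replacing a carbon-based group by chloro; going the other way, from chloro to a carbon-based group, lowered the number, modestly in the case of hydroxymethyl. The entering (propanoyloxy)methyl group is the ester of that hydroxymethyl group, so a modest fall in this assay is expected, roughly a 2.1-fold lower number from compound 3 to compound 4 (0.32 log units; beyond the scatter). For compound 4 the estimate is 100 nM, with a range from 30 nM to 350 nM.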

Compound 4, half-maximal inhibitory concentration: 130 nM
For compound 4 the middle estimate is 1.3-fold (0.11 log units) below the measured one; the range from low to high includes it.
By their numbers in this assay, from the lowest: compound 2; then compounds 1, 4 and 3 (each within the scatter of the next).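

In this assay, putting a propanoyl group on the oxygen of the hydroxymethyl group weakens the effect modestly (a 2.1-fold higher number from compound 2 to compound 4 (0.32 log units; beyond the scatter)), so at this position the ester does not match the free hydroxymethyl group of compound 2. The (propanoyloxy)methyl group has 6 heavy atoms where chloro has 1, yet this larger group leaves the number within the scatter of the chloro compound (a 1.6-fold lower number from compound 3 to compound 4 (0.21 log units; within the scatter)) and of the ethyl compound (no change at the digits printed from compound 1 to compound 4 (within the scatter)), so on this aromatic carbon, added size alone brings no clear change among these compounds. Nothing measured here explains these differences.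

The compounds shown leave open how an aminomethyl group, a carboxylic acid or a longer ester chain on this aromatic carbon would read. They also leave open whether these small differences hold in other cell lines.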